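Halogen swap on the shared core: compound 1 to compound 4

The compounds below may be only part of what the source reports. "The series", "measured", "known", "first", "only" and "open" are said of these compounds alone.

compound 1 `O=C(c1ccc(Cl)cc1)N1CC(c2nc(-c3cccc(F)c3)no2)C1` — > 10000 nM
compound 2 `COC1CCCN(C(=O)N2CC(c3nc(-c4cccc(Cl)c4)no3)C2)C1` — 1830 nM
compound 3 `Cc1ccc(S(=O)(=O)N2CC(c3nc(-c4cccc(C)c4)no3)C2)cc1` — 670 nM

Three compounds of the shared core have been run in an assay on HEK293 cells for negative allosteric modulation of metabotropic glutamate receptor 5 (Homo sapiens), read by FLIPR; on this read-out lower numbers stand for stronger inhibition and higher numbers for weaker inhibition. In this assay compound 1 gives > 10000 nM, which is a limit of the assay and not a number. Compound 2 reads 1830 nM in this assay, and compound 3 reads 670 nM. Compound 1 therefore stands at the weak end of the numbers shown, resting on (the limit of > 10000 nM in this assay, at which 1 of the 3 values shown sits). Compound 4 `O=C(c1ccc(F)cc1)N1CC(c2nc(-c3cccc(F)c3)no2)C1` differs from compound 1 in one place: fluoro in place of chloro on an aromatic carbon. Among the compounds with values here, no step between measured compounds covers this change, so the series gives no measure of its size. The expected step is a step that the limit leaves unreadable from compound 1 to compound 4, no more than the usual scatter in either direction. For compound 4 the estimate in this assay is 15000 nM, ranging from 5000 nM to 50000 nM, and a limit is again expected most often.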

Compound 4, half-maximal inhibitory concentration: > 10000 nM
Compound 4 ended at the assay's limit; the forecaster's own chance of this, stated with the estimate: 70%; the middle value lies beyond the limit too.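

Within the data shown here, compound 1 and compound 4 both rest on a limit in this assay, not on a number, so no step between them can be read. The compounds shown leave open whether 4-chlorophenyl to 4-fluorophenyl shifts inhibition at all.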